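The source may report more compounds than this note shows. Statements on the series, on what has been measured and on what is new or still open speak of the compounds shown alone.

In a functional assay on K562 cells (Homo sapiens) for cytotoxicity, read by MTT assay, with a stated time of 48 h (a lower number here means a stronger inhibitor, a higher number a weaker inhibitor), compound 1 (`Cc1ccccc1CN1CCN(C(=O)CN[C@H]2CCN(S(=O)(=O)Cc3ccccc3)C2)CC1`) gives 10200 nM and compound 2 (`O=C(CN[C@H]1CCN(S(=O)(=O)Cc2ccccc2)C1)N1CCN(Cc2cccc(Cl)c2)CC1`) gives 8600 nM with no order between them, the step being a 1.2-fold lower number from compound 1 to compound 2 (0.07 log units; within the scatter) in this pair. Compound 3 (`Cc1cc(C)c(CN2CCN(C(=O)CN[C@H]3CCN(S(=O)(=O)Cc4ccccc4)C3)CC2)c(C)c1`) stands lowest of the three at 3300 nM on these numbers. Both steps into it clear the scatter but stay modest, namely a 3.1-fold lower number from compound 1 to compound 3 (0.49 log units; beyond the scatter) and a 2.6-fold lower number from compound 2 to compound 3 (0.42 log units; beyond the scatter) as measured.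

Compound 4 (`COc1cccc(CN2CCN(C(=O)CN[C@H]3CCN(S(=O)(=O)Cc4ccccc4)C3)CC2)c1`) comes next, with 3-methoxyphenyl in place of 2,4,6-trimethylphenyl on a saturated chain carbon bound to an amine nitrogen in a ring. Among the measured compounds shown here, no measured compound carries the 3-methoxyphenyl, so there is no direct precedent for it. The nearest guides are the two steps above, read in reverse, since each of them swaps the 2,4,6-trimethylphenyl for another aryl group. Read that way, a 3.1-fold lower number from compound 1 to compound 3 (0.49 log units; beyond the scatter) and a 2.6-fold lower number from compound 2 to compound 3 (0.42 log units; beyond the scatter) both point to a modest rise on leaving the 2,4,6-trimethylphenyl, and the level shared by compound 1 and compound 2 is the likely landing zone. In this assay a modest move toward a weaker inhibitor is therefore expected, not a large one. The step expected for compound 4 is a 2.4-fold higher number from compound 3 to compound 4 (0.38 log units; beyond the scatter) on this estimate. The estimated value for compound 4 is 8000 nM with an expected range from 4000 nM to 15000 nM until the measurement is in.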

Compound 4, half-maximal inhibitory concentration: 60800 nM
The estimate for compound 4 lay 7.6-fold (0.88 log units) below the measured number; measured number outside the range, above it.
By their numbers in this assay, from the lowest: compound 3; then compounds 2 and 1 (each within the scatter of the next); then compound 4.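

Working notes on the series: in this assay the aryl group on a saturated chain carbon bound to an amine nitrogen in a ring proves far less tolerant than compounds 1 to 3 suggested, giving the first large step at this position (an 18-fold higher number from compound 3 to compound 4 (1.27 log units; beyond the scatter)). The 3-methoxyphenyl also separates from the level of the other two aryl groups, which themselves differ only within the scatter (a 1.2-fold lower number from compound 1 to compound 2 (0.07 log units; within the scatter)), as seen in the steps with methoxy replacing chloro (a 7.1-fold higher number from compound 2 to compound 4 (0.85 log units; beyond the scatter)) and with 3-methoxyphenyl replacing 2-methylphenyl (a 6.0-fold higher number from compound 1 to compound 4 (0.78 log units; beyond the scatter)). Among the compounds shown here, compound 4 is the only member with a hydrogen-bond acceptor counted in this aryl group, but a single compound establishes no pattern, and nothing available accounts for the size of this shift.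

Still open, from the compounds shown here alone, is whether a hydroxy group or an amine on the same aryl group would track with compound 4. An unsubstituted phenyl would also help show whether the methoxy raises the number or the methyl groups of compound 3 lower it.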